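Methyl for methoxy on the core of compound 2

This account rests on a few compounds, and the source may have more. Where it says the series, first, only, none or still open, it means among the compounds named here.

Two compounds of this series have numbers in an assay on IMR-32 cells for displacement of a labelled ligand from corticotropin-releasing factor receptor 1 (Homo sapiens), read by scintillation counting, with a stated time of 2 h; on this read-out lower numbers stand for stronger inhibition and higher numbers for weaker inhibition. Compound 1 `CCc1nc(NC(CC)CC)c(OC)nc1-c1ccc(OC(F)F)cc1Cl` gives 1.4 nM in this assay. Compound 2 `CCC(CC)Nc1nc(OC)c(-c2ccc(Cl)cc2Cl)nc1C` gives 14.4 nM in this assay, the higher of the two numbers, and the gap between compound 1 and compound 2 lies beyond the scatter. The next compound, compound 3 `CCC(CC)Nc1nc(C)c(-c2ccc(Cl)cc2Cl)nc1C`, differs from compound 2 in one place: methyl in place of methoxy on an aromatic carbon of a six-membered aromatic ring with 2 nitrogen. Among the compounds with values here, no pair of measured compounds shows this change, so its size cannot be read from the series. The expectation is a small step from compound 2 to compound 3, upward if any, around the scatter: a 1.5-fold higher number from compound 2 to compound 3 (0.18 log units; within the scatter). Compound 3 is estimated at 22 nM in this assay, with a range from 7 nM to 70 nM.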

Compound 3, inhibition constant: 27 nM
For compound 3 the middle estimate is 1.2-fold (0.09 log units) below the measured one; the range from low to high includes it.
By their numbers in this assay, from the lowest: compound 1; then compounds 2 and 3 (each within the scatter of the next).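

Methyl in place of methoxy on an aromatic carbon, next to the ring nitrogen, gives a 1.9-fold higher number from compound 2 to compound 3 (0.27 log units; within the scatter) in this assay, the first direct reading of this change in the series. At this position, on the core shared by compound 2 and compound 3, the two groups cannot be told apart in this read-out, so the hydrogen-bond acceptor counted on the methoxy group can leave without a step beyond the scatter. Nothing at hand accounts for this result.

As far as these compounds go, how an ethoxy group, a dimethylamino group or a chlorine atom would read at this position remains open. Also open, from the compounds shown here alone, is whether the same change gives a similar step on compound 1, which carries different groups elsewhere on the core and on the aryl ring.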